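The compounds below may be only part of what the source reports. "The series", "measured", "known", "first", "only" and "open" are said of these compounds alone.

Working notes on the series. In an ADME assay on L929 cells (Mus musculus) for cytotoxicity, read by resazurin assay, with a stated time of 48 h (a lower number here means that less compound is tolerated, a higher number that more compound is tolerated), compound 1 `C#CCn1c2ccc([N+](=O)[O-])cc2c(=O)n1Cc1ccccc1` gives 195000 nM. Compound 2 `O=c1c2cc([N+](=O)[O-])ccc2n(CCCO)n1Cc1ccccc1` stands only at a limit of the assay, > 256000 nM. Compound 3 `CC(=O)OCCn1c2ccc([N+](=O)[O-])cc2c(=O)n1Cc1ccccc1` differs from it by acetoxy in place of hydroxymethyl on a saturated chain carbon, two bonds along the chain from an aromatic nitrogen, with acetoxy in place of hydroxymethyl on a saturated chain carbon, two bonds along the chain from an aromatic nitrogen. Among the measured compounds shown here, the only measured step is an at least 1.3-fold higher number from compound 1 to compound 2 (0.11 log units; that floor lies within the scatter). For the measured compounds named here, with that step as the sole guide, no change beyond the scatter is expected in this assay. The estimated move is an at least 1.2-fold lower number from compound 2 to compound 3 (0.10 log units; that floor lies within the scatter). For compound 3 the estimate is 200000 nM, with an expected range of 90000 nM to 350000 nM.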

Compound 3, concentration lethal to 50% of the cells: > 256000 nM
Compound 3: a limit, no number (the forecaster's own chance of this, stated with the estimate: 35%); middle value at least 1.2-fold (0.10 log units) from the limit.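

In this assay, compound 3 also stands at a limit of the assay, so the chain tolerates acetoxy as well as a free hydroxyl, with 0 hydrogen-bond donors in the entering group against 1 in the group that leaves. Among the compounds shown here, the one readable step is an at least 1.3-fold higher number from compound 1 to compound 3 (0.11 log units; that floor lies within the scatter), which is only a floor. The step between compound 2 and compound 3 cannot be read, because both are limits: the limit of > 256000 nM in this assay, at which 2 of the 3 values shown sit.

Open, on these data alone, are the true values behind both limits. Also open, as far as these compounds go, is whether an amine or a carboxylic acid on this chain, or a longer chain, would give a number inside the range of the assay.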